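The source may hold more compounds than are shown below. What is called first, only, known or untested is meant among the compounds shown, and "the series" means these compounds.

Compound 1 `Cc1cccc(NC(=O)CS(=O)(=O)c2nccc(Oc3c(C)cc(C#N)cc3C)n2)c1`: 25700 nM
Compound 2 `Cc1cc(C#N)cc(C)c1Oc1ccnc(S(=O)(=O)CC(=O)Nc2ccc(Cl)cc2)n1`: 16600 nM
Compound 3 `Cc1cc(C#N)cc(C)c1Oc1ccnc(S(=O)(=O)CC(=O)Nc2cc(Cl)cc(Cl)c2)n1`: 24000 nM

In an ADME assay on MT4 cells (Homo sapiens) for cytotoxicity, read by MTT assay, with a stated time of 4 days (a higher number here means that more compound is tolerated, a lower number that less compound is tolerated), compound 3 gives 24000 nM, a value within the scatter of both other compounds, so the three cannot be put in any order. The next compound, compound 4 `Cc1cc(C#N)cc(C)c1Oc1ccnc(S(=O)(=O)CC(=O)Nc2ccc(C#N)cc2F)n1`, keeps the shared core and has 4-cyano-2-fluorophenyl in place of 3,5-dichlorophenyl on an amide-type nitrogen.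

Among the measured compounds shown here, three measured steps bear on this change, since each exchanges the group at that same place. They are a 1.5-fold lower number from compound 1 to compound 2 (0.19 log units; within the scatter), a 1.1-fold lower number from compound 1 to compound 3 (0.03 log units; within the scatter) and a 1.4-fold higher number from compound 2 to compound 3 (0.16 log units; within the scatter). All three are small, and none leaves the scatter. For the measured compounds named here, no measured compound carries a nitrile or a fluorine on this group, so the evidence is indirect and the range must stay wide. Even so, with compound 3 at 24000 nM and the steps above so small, no shift beyond the scatter is expected in this assay, and no direction can be favoured with any confidence. The expected change is a 1.2-fold lower number from compound 3 to compound 4 (0.08 log units; within the scatter), which would be too small to read as a real difference. For compound 4 the estimated value is 20000 nM, with an expected range from 8000 nM to 50000 nM.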

Compound 4, half-maximal cytotoxic concentration: > 268000 nM
Compound 4 gave a limit, no number (the forecaster's own chance of this, stated with the estimate: 15%); at least 13-fold (1.12 log units) between middle value and limit.
By their numbers in this assay, from the lowest: compounds 2, 3 and 1 (each within the scatter of the next). At a limit, above all of these: compound 4.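

In this assay compound 4 gives a limit, not a number: the limit of > 268000 nM in this assay, at which 1 of the 4 values shown sits.

The earlier exchanges among 3-methylphenyl, 4-chlorophenyl and 3,5-dichlorophenyl on the amide-type nitrogen all stayed within the scatter, so this place could have seemed indifferent to the group it carries. With 4-cyano-2-fluorophenyl on that nitrogen, each step is large and beyond the scatter (an at least 11-fold higher number from compound 3 to compound 4 (1.04 log units; beyond the scatter)), (an at least 16-fold higher number from compound 2 to compound 4 (1.20 log units; beyond the scatter)) and (an at least 10-fold higher number from compound 1 to compound 4 (1.01 log units; beyond the scatter)). The shared core is unchanged in these steps, so the group at this one place can move the tolerated concentration substantially, although the three earlier groups gave no sign of this.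

As far as these compounds go, whether a nitrile alone or a fluorine alone on this phenyl ring would produce such a step stays open, as 4-cyano-2-fluorophenyl brings both at once. Also open, from the compounds shown here alone, are how far the true value of compound 4 lies past its limit and how an amine or a carboxylic acid on this ring would behave in this assay.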